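A few compounds are considered here, and "the series" means these few. Any claim that something is new, unique, unknown or untested is made for them only; others in the source may bear on it.

Working notes on the series. In a functional assay on HCT-15 cells (Homo sapiens) for cytotoxicity, read by sulforhodamine B assay, with a stated time of 72 h (a lower number here means a stronger inhibitor of growth, a higher number a weaker inhibitor of growth), compound 1 `O=C(Nc1ccccc1O)C1CCc2ccccc2N1C(=O)c1ccc(Cl)cc1` gives 20200 nM. Going by the values given here, of the three compounds measured so far, compound 1 stands second highest. Compound 3 `O=C(Nc1ccccc1)C1CCc2ccccc2N1`, which lacks the acyl group on the ring nitrogen, gives 109000 nM. Compound 2 `O=C(Nc1ccccc1C(F)(F)F)C1CCc2ccccc2N1C(=O)c1ccc(Cl)cc1` gives 839 nM. Among the compounds with values here, the one single-point step measured to date is a 24-fold lower number from compound 1 to compound 2 (1.38 log units; beyond the scatter), and it concerns the ring on the amide nitrogen, not the acyl group on the ring nitrogen.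

Compound 4 `O=C(Nc1ccccc1O)C1CCc2ccccc2N1C(=O)c1cccc(Cl)c1` differs from compound 1 by 3-chlorophenyl in place of 4-chlorophenyl on a carbonyl carbon. Within the data shown here, no measured step in this set touches the acyl group; the data hold nothing on moving the chlorine within that ring. Among the measured compounds shown here, with no bearing step to draw on, the working assumption is a step of no size beyond the scatter. Compound 4 is therefore expected to give 20000 nM, with a range of 7000 nM to 60000 nM. The step of a 1.0-fold lower number from compound 1 to compound 4 (0.00 log units; within the scatter) is an estimate resting only on the absence of any contrary evidence.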

Compound 4, concentration for 50% growth inhibition: 23100 nM
Compound 4: middle estimate off by 1.2-fold (0.06 log units), on the low side; the range from low to high includes it.
By their numbers in this assay, from the lowest: compound 2; then compounds 1 and 4 (each within the scatter of the next); then compound 3.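

Going by these compounds alone, this is the first measured step at the acyl group: in this assay, 3-chlorophenyl in place of 4-chlorophenyl on a carbonyl carbon gives a 1.1-fold higher number from compound 1 to compound 4 (0.06 log units; within the scatter). With the hydroxy group of compound 1 kept on the amide ring, the two chlorine placements cannot be told apart in this assay, whereas the change on the amide ring gives a 24-fold lower number from compound 1 to compound 2 (1.38 log units; beyond the scatter). No available evidence accounts for the two chlorophenyl groups reading alike.

The compounds shown leave open whether the same holds alongside the trifluoromethyl group of compound 2, where the numbers lie much lower. They also leave open whether a group other than chlorine on the acyl ring, such as an amine or a carboxylic acid, would give a number beyond the scatter from compound 1.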